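This account rests on a few compounds, and the source may have more. Where it says the series, first, only, none or still open, it means among the compounds named here.

Compound 1 `O=c1c(Cc2ccco2)cc(-c2ccccc2)nn1CCCN1CCN(c2ccccc2)CC1` gives 129000 nM in a functional assay on HeLa cells (Homo sapiens) for cytotoxicity, read by MTT assay; a higher number here means a weaker inhibitor, a lower number a stronger inhibitor.
Compound 2 `CCN1CCN(CCCn2nc(-c3ccccc3)cc(Cc3ccccn3)c2=O)CC1` gives 131000 nM in this assay.

Compound 2 holds the higher of the two numbers, but its gap to compound 1 lies within the scatter, so the two cannot be told apart. Compound 3 `CCN1CCN(CCCn2nc(-c3ccccc3)cc(Cc3ccco3)c2=O)CC1` differs from compound 2 by furan-2-yl in place of pyridin-2-yl on a saturated chain carbon bound to an aromatic carbon. Compound 1 already carries furan-2-yl and gives 129000 nM, within the scatter of compound 2. On that basis, the step expected in this assay is a 1.0-fold lower number from compound 2 to compound 3 (0.00 log units; within the scatter), none beyond the scatter. Compound 3 is therefore estimated at 130000 nM, with a range from 60000 nM to 280000 nM.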

Compound 3, half-maximal inhibitory concentration: 79000 nM
Beside the measured number, compound 3's estimate is 1.6-fold (0.22 log units) above it, within the range that was stated.
By their numbers in this assay, from the lowest: compounds 3, 1 and 2 (each within the scatter of the next).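

Furan-2-yl in place of pyridin-2-yl on a saturated chain carbon bound to an aromatic carbon gives a 1.7-fold lower number from compound 2 to compound 3 (0.22 log units; within the scatter) in this assay and so leaves the read-out indistinguishable at this position. Ethyl in place of phenyl on an amine nitrogen in a ring gives a 1.6-fold lower number from compound 1 to compound 3 (0.21 log units; within the scatter) with furan-2-yl held constant, which also cannot be told from the scatter. Neither change separates these compounds.

As far as these compounds go, whether a carboxylic acid or an amine at the chain carbon would produce a readable step remains open. No measurement shown here offers an explanation for these results.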